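Methyl-to-hydrogen step on the shared core in IDO1 inhibition

A few compounds are considered here, and "the series" means these few. Any claim that something is new, unique, unknown or untested is made for them only; others in the source may bear on it.

Measured so far:
compound 1 `Cc1nc(NCc2cccc(C(=O)O)c2)c2cn[nH]c2n1`: 5%
compound 2 `O=C(CNc1cc(Br)cc2[nH]ncc12)Nc1ccc(C(=O)O)cc1`: 12%
compound 3 `O=C(O)c1ccc(CNc2cc(Br)cc3[nH]ncc23)cc1`: 49%

In an assay for inhibition of Indoleamine 2,3-dioxygenase 1 (Homo sapiens), read by spectrophotometry, with a stated time of 180 min, tested at 10 uM (a higher number here means a stronger effect of the compound at the concentration tested, a lower number a weaker effect), compound 1 gives 5%, the lowest of the three numbers. Compound 2 gives 12%, which lies within the scatter of compound 1. Compound 3 gives 49%, beyond the scatter above compound 1.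

Compound 4 `O=C(O)c1cccc(CNc2ncnc3[nH]ncc23)c1` differs from compound 1 in one place: hydrogen in place of methyl on an aromatic carbon. Within the data shown here, no measured pair shows this change, so the size of its step is open. With one heavy atom removed and no donor or acceptor count altered, a step from compound 1 to compound 4 of no more than the scatter is expected, a number 3 percentage points higher from compound 1 to compound 4 (within the scatter). Compound 4 is therefore estimated at 8%, between 0% and 25%.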

Compound 4, a percentage reported as inhibition, at one concentration (the size of the read-out at that concentration, not a potency): 2%
Beside the measured number, compound 4's estimate is 6 percentage points above it; low and high end bracket the measured number.
By their numbers in this assay, from the lowest: compounds 4, 1 and 2 (each within the scatter of the next); then compound 3.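

In this assay, hydrogen in place of methyl on the aromatic carbon between two ring nitrogen atoms gives a number 3 percentage points lower from compound 1 to compound 4 (within the scatter). This first measured pair shows no effect of the methyl beyond the scatter at this position, but both read-outs are low, so little room remains to detect a loss. No evidence on a cause is at hand.

On these data alone, whether an amine, a methoxy group or a longer chain on this aromatic carbon would raise the read-out stays open. So does whether the step stays this small in a compound with a larger read-out.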